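Benzyl in Place of Butoxy on the Aryl Urea

This account rests on a few compounds, and the source may have more. Where it says the series, first, only, none or still open, it means among the compounds named here.

Of the compounds shown here, three carry numbers so far in a functional assay on IGROV-1 cells (Homo sapiens) for inhibition, read by sulforhodamine B assay, with a stated time of 48 h; on this read-out higher numbers stand for weaker inhibition of growth and lower numbers for stronger inhibition of growth. Compound 1 `COc1ccc(NC(=O)Nc2n[nH]c3ccccc23)cc1`, built with its urea in a different arrangement, gives in this assay only a limit, > 100000 nM; one of the three values shown sits at that limit (the limit of > 100000 nM in this assay, at which 1 of the 3 values shown sits). Compound 2 `CCCCOc1ccc(NC(=O)n2nc(N)c3ccccc32)cc1`, which carries a butoxy group on its aryl ring, gives in this assay 35500 nM. Compound 3 `Nc1nn(C(=O)Nc2c(F)cccc2F)c2ccccc12`, with two fluorines on its aryl ring, gives in this assay 7700 nM. Of the two numbers that are not limits, compound 2 stands highest, and compound 3 is its nearest neighbour at a lower number by a margin beyond the usual scatter.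

Compound 4 `Nc1nn(C(=O)Nc2ccc(Cc3ccccc3)cc2)c2ccccc12` has not yet been measured in this assay. It differs from compound 2 in one place: benzyl in place of butoxy on an aromatic carbon. Within the data shown here, no pair of measured compounds isolates this change, and compound 1, whose value is a limit, gives no guide to its size. Since compound 3 reaches 7700 nM with another aryl pattern on the same core, compound 4 is expected to move toward stronger inhibition by a step of a 2.4-fold lower number from compound 2 to compound 4 (0.37 log units; beyond the scatter) that lies beyond the scatter. Compound 4 is estimated at 15000 nM, with a range from 4000 nM to 60000 nM.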

Compound 4, concentration for 50% growth inhibition: 6980 nM
For compound 4 the middle estimate is 2.1-fold (0.33 log units) above the measured one, and the stated range covers the measured number.
By their numbers in this assay, from the lowest: compounds 4 and 3 (each within the scatter of the next); then compound 2. At a limit, above all of these: compound 1.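

In this assay, this position on the aryl ring, para to a large group, proves sensitive to what it carries, since the swap of butoxy for benzyl gives a 5.1-fold lower number from compound 2 to compound 4 (0.71 log units; beyond the scatter), a modest step but one beyond the scatter. The change also shows that the chain oxygen, the one hydrogen-bond acceptor in the leaving butoxy, can be lost here without weakening inhibition of growth, and that a six-membered aromatic ring of carbon only is accepted in its place. Among these compounds, nothing measured so far accounts for the size or direction of this step.

The swap alters the oxygen, the ring and the heavy-atom count together, so these compounds leave open which of them carries the step. A plain butyl or pentyl chain, a phenoxy group or an amine at the same place would begin to pull these apart, and a carboxylic acid there would test how far the position tolerates a change of a different kind.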